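The compounds below may be only part of what the source reports. "The series", "measured", "known", "first", "only" and "open" are said of these compounds alone.

Compound 1 `Cc1ccccc1Nc1nc2nonc2nc1Nc1ccccc1C` gives 2300 nM in an assay on mitochondria from L6 cells (Rattus norvegicus) for activation, with a stated time of 90 min; on this read-out higher numbers stand for an effect only at larger amounts of compound and lower numbers for an effect already at smaller amounts.
Compound 2 `Fc1ccc(Nc2nc3nonc3nc2Nc2ccccc2F)cc1` gives 2300 nM in this assay.

Compound 2 stands level with compound 1 at the digits shown; the two values lie within the scatter of each other, so no difference between them can be claimed. Compound 3 `Cc1ccccc1Nc1nc2nonc2nc1Nc1ccccc1F` is not yet measured. It differs from compound 2 by 2-methylphenyl in place of 4-fluorophenyl on a nitrogen on an aromatic ring. Among the compounds with values here, no step between measured compounds is available, so only this pair of values guides the expectation. Since compound 1, which already carries 2-methylphenyl on both nitrogens, gives 2300 nM, the expected step is none beyond the scatter: no change at the digits printed from compound 2 to compound 3 (within the scatter). Compound 3 is therefore estimated at 2300 nM, within 1200 nM to 4600 nM.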

Compound 3, half-maximal effective concentration: 1100 nM
Compound 3: the middle estimate sits 2.1-fold (0.32 log units) above what was measured; the measured number lies below the stated range.
By their numbers in this assay, from the lowest: compound 3; then compounds 1 and 2 (each within the scatter of the next).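

In this assay, 2-methylphenyl in place of 4-fluorophenyl on a nitrogen gives a 2.1-fold lower number from compound 2 to compound 3 (0.32 log units; beyond the scatter), and fluoro in place of methyl on an aromatic carbon gives a 2.1-fold lower number from compound 1 to compound 3 (0.32 log units; beyond the scatter). Compound 1 and compound 2 gave no hint of this, yet compound 3, with one methyl and one fluoro, stands modestly apart from both. No measurement given here bears on the reason for these steps. On these data alone, whether an amine, a carboxylic acid or a longer chain in place of the methyl or fluoro would move the number further remains open.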